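Swapping methyl for tert-butyl on an inactive triazole scaffold

This account rests on a few compounds, and the source may have more. Where it says the series, first, only, none or still open, it means among the compounds named here.

Measured compounds:
compound 1, `Cc1ccc(-c2cn(C/C=C3\OC(=O)C(OCc4ccccc4)=C3OCc3ccccc3)nn2)cc1`, > 100000 nM
compound 2, `O=C1NC(O)(CCn2cc(Cc3ccccc3)nn2)C(OCc2ccccc2)=C1OCc1ccccc1`, > 100000 nM

Of the compounds shown here, two have been tested in a functional assay on PC-3 cells (Homo sapiens) for antiproliferative activity, read by MTT assay, with a stated time of 24 h; a lower number here means a stronger inhibitor, a higher number a weaker inhibitor. Compound 1 reaches only the limit of this assay, > 100000 nM, and not a number. Compound 2 likewise gives only a limit, > 100000 nM. Compound 1 therefore stands at the limit of > 100000 nM in this assay, at which 2 of the 2 values shown sit, with no measured value to rank it against any other compound.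

Compound 3, `CC(C)(C)c1ccc(-c2cn(C/C=C3\OC(=O)C(OCc4ccccc4)=C3OCc3ccccc3)nn2)cc1`, is not yet measured. It differs from compound 1 by tert-butyl in place of methyl on an aromatic carbon. For the measured compounds named here, no pair of measured compounds differs in a single place, so no measured step is available for comparison; the only guide is that both measured compounds sit at the limit.

Given that compound 1 shows > 100000 nM, compound 3 is expected to remain at or near that limit, with a step of a number no higher from compound 1 to compound 3 (the limit leaves the size open) that is not expected to go beyond the scatter. The estimate for compound 3 is 100000 nM, in the range 30000 nM to 300000 nM.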

Compound 3, half-maximal inhibitory concentration: > 100000 nM
Compound 3: only a limit was reported; the forecaster's own chance of this, stated with the estimate: 80%; the middle value sits exactly at the limit.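

No step can be read between compound 1 and compound 3, since each gives only a limit and not a number: the limit of > 100000 nM in this assay, at which 3 of the 3 values shown sit.

The compounds shown leave open whether tert-butyl in place of methyl on an aromatic carbon makes any difference, and where any of the three compounds would fall as a measured number.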